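A few compounds are considered here, and "the series" means these few. Any claim that something is new, unique, unknown or untested is made for them only; others in the source may bear on it.

In a functional assay on MCF7 cells (Homo sapiens) for antiproliferative activity, with a stated time of 5 days (on this read-out lower numbers stand for stronger inhibition and higher numbers for weaker inhibition), compound 1 `O=Cc1c(-c2ccccc2)[nH]c2ccccc12` gives 650 nM. Compound 2 `COc1ccc(-c2[nH]c3ccc(F)cc3c2C=C(C#N)C#N)cc1` gives 310 nM, the lower of the two numbers, and its gap to compound 1 lies just beyond the usual scatter of repeated measurements. For the measured compounds named here, the data hold no measured pair that differs in one place, so no single structural change has yet been tested on its own.

Compound 3 `CCCCc1ccc2[nH]c(-c3ccc(OC)cc3)c(C=C(C#N)C#N)c2c1` has not yet been measured. It differs from compound 2 in one place, with butyl in place of fluoro on an aromatic carbon of the shared core: butyl in place of fluoro on an aromatic carbon. Going by the values given here, nothing measured so far speaks directly to this exchange, so the expectation remains loose. A moderate gain in potency is expected in this assay, meaning a lower number than that of compound 2, although a result within the scatter remains possible. The estimated change is a 3.9-fold lower number from compound 2 to compound 3 (0.59 log units; beyond the scatter). For compound 3, the expected value is 80 nM, with an estimated range from 15 nM to 400 nM.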

Compound 3, half-maximal inhibitory concentration: 13 nM
For compound 3 the middle estimate is 6.2-fold (0.79 log units) above the measured one, outside the stated range (below it).
By their numbers in this assay, from the lowest: compound 3; then compound 2; then compound 1.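

In this assay, for the compounds shown here, the exchange of fluoro for butyl gives a 24-fold lower number from compound 2 to compound 3 (1.38 log units; beyond the scatter), the first measured step in which only one place changes, and it is large. It shows that this aromatic carbon, on a six-membered aromatic ring of carbon only within a fused or bridged system of two rings, is not indifferent to what it carries, and that butyl, with 4 heavy atoms in place of 1, is accepted there with a lower number, while the rest of compound 2 stays the same. Nothing measured here gives a reason for a step of this size. Since this is a single exchange, the compounds shown leave open whether the gain belongs to butyl itself or would also appear with a shorter chain such as ethyl, a longer chain such as hexyl, a branched chain such as isobutyl, or a ring-bearing group such as benzyl. They also leave open how an amine or a carboxylic acid on the same carbon would read in this assay, and whether butyl gives a step of similar size when the methoxy group elsewhere on the molecule is replaced.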